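Swapping Propyl for Acetyl in a Leukotriene Receptor Series

The source may report more compounds than this note shows. Statements on the series, on what has been measured and on what is new or still open speak of the compounds shown alone.

Compound 1 `CCCc1cc(C(C)=O)c(O)cc1OCCCCC#N` stands lowest of the two compounds measured in an assay on isolated protein for binding affinity to leukotriene B4 receptor 1 (Homo sapiens), tested at 1 uM (on this read-out higher numbers stand for more inhibition at the one concentration tested (going by the name of the read-out) and lower numbers for less inhibition), giving 37%. Compound 2 `CSCc1cc(C(C)=O)c(O)cc1OCCCCCCC#N` reaches 64% in this assay, a gap beyond the usual scatter. The step under review leads to compound 3 `CC(=O)c1cc(C(C)=O)c(OCCCCC#N)cc1O`, which differs from compound 1 in one place: acetyl in place of propyl on an aromatic carbon. Within the data shown here, no measured pair shows this change, so its effect in this assay is an open question. No step beyond the scatter is expected here, with a number 2 percentage points lower from compound 1 to compound 3 (within the scatter) as the estimated shift. Compound 3 is accordingly expected to give about 35%, most likely between 15% and 58%.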

Compound 3, a percentage reported as inhibition, at one concentration (the size of the read-out at that concentration, not a potency): 0%
Estimate against measurement, compound 3: 35 percentage points above; the measured number lies below the stated range.
By their numbers in this assay, from the lowest: compound 3; then compound 1; then compound 2.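

In this assay, acetyl in place of propyl on an aromatic carbon gives the first step measured at this position, a number 37 percentage points lower from compound 1 to compound 3 (beyond the scatter). So at this place, para to a hydroxy group, the change costs far more than the scatter, although both groups have the same count of heavy atoms. Nothing available explains this loss. Going by these compounds, what an amine, a carboxylic acid or a longer alkyl chain would do at this position stays open. So does whether the same swap would cost as much in the core of compound 2.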